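A few compounds are considered here, and "the series" means these few. Any claim that something is new, unique, unknown or untested is made for them only; others in the source may bear on it.

Compound 1 `CSCC[C@H](NC(=O)CN(c1ncnc2c1ncn2C1CCCCO1)C1CC1)C(=O)OCc1ccccc1` stands at the top of the two numbers recorded. In a functional assay on the whole organism (Tail, strain ICR) with Mus musculus as the target, in the tail flick test, with a stated time of 120 min, at a dose of 25 umol/kg by the oral route (a lower number here means a weaker effect, a higher number a stronger effect of the compound at the dose given), compound 1 gives 28.7%, while compound 2 `N=C(N)NCCC[C@H](NC(=O)CN(c1nc(Cl)nc2[nH]cnc12)C1CC1)C(=O)O`, which differs from it in several places at once, gives 17% in this assay, a gap beyond the usual scatter. Among the compounds with values here, no pair of measured compounds differing in one place is available, so the step to compound 3 `O=C(CN(c1ncnc2c1ncn2C1CCCCO1)C1CC1)N[C@@H](CC(=O)OCc1ccccc1)C(=O)OCc1ccccc1` has no measured counterpart.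

The change from compound 1 to compound 3 is benzyloxycarbonyl in place of (methylsulfanyl)methyl on a saturated chain carbon, two bonds along the chain from an amide-type nitrogen and a carbonyl carbon. Within the data shown here, with only one starting value and no step of the same kind to lean on, no change beyond the scatter in either direction is expected for this exchange; the estimated step of a number 5.7 percentage points lower from compound 1 to compound 3 (within the scatter) in this assay is therefore small and uncertain. Compound 3 is expected to give 23% in this assay, within a range from 5% to 45%.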

Compound 3, a percentage reported as activity, at one dose (the size of the read-out at that dose, not a potency): 7.82%
Compound 3: the middle estimate sits 15.2 percentage points above what was measured; the range from low to high includes it.
By their numbers in this assay, from the lowest: compounds 3 and 2 (each within the scatter of the next); then compound 1.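

In this assay, within the data shown here, benzyloxycarbonyl in place of (methylsulfanyl)methyl gives a number 20.9 percentage points lower from compound 1 to compound 3 (beyond the scatter), the only single-place step available in this set. It shows that the saturated chain carbon, two bonds along the chain from an amide-type nitrogen and a carbonyl carbon, is not indifferent to the group it carries: here, the read-out at the dose given falls beyond the scatter when the entering group brings a six-membered aromatic ring of carbon only and the sulfur leaves. No available evidence bears on why this step occurs.

On these data alone, whether a carboxylic acid, an amine or a longer chain ending in methylsulfanyl at this place would keep the read-out of compound 1 remains open. A single exchange also cannot show whether the loss follows the ester, the aromatic ring or the departure of the sulfur.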